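The source may report more compounds than this note shows. Statements on the series, on what has been measured and on what is new or still open speak of the compounds shown alone.

Measured so far:
Compound 1, `Nc1ncc(-c2ccc(F)cc2)c(-c2ccccc2)n1`, gives > 80% in an assay on CHO cells for displacement of a labelled ligand from adenosine receptor A1 (Homo sapiens), read by scintillation counting, with a stated time of 1 h, tested at 1 uM (on this read-out lower numbers stand for less inhibition and higher numbers for more inhibition at the one concentration tested (going by the name of the read-out)), and this reading is a limit of the assay rather than a number.
Compound 2, `O=C(Nc1ncc(-c2cccc(Cl)c2)c(-c2ccccc2)n1)C1CCCC1`, gives 47% in this assay.

Within the data shown here, compound 2 therefore supplies the only plain number among the two readings. The other reading, that of compound 1, is the limit of > 80% in this assay, at which 1 of the 2 values shown sits. Among the measured compounds shown here, no step between two measured compounds is available here, so the comparison rests on the two values alone.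

Compound 3, `OCCCNc1ncc(-c2cccc(Cl)c2)c(-c2ccccc2)n1`, has not yet been measured. It differs from compound 2 in one place: 3-hydroxypropyl in place of cyclopentylcarbonyl on a nitrogen on an aromatic ring. The group that enters is shorter than the one that leaves and carries a hydrogen-bond donor where the leaving group had none.

In this assay a modest rise is expected for this change, a number 13 percentage points higher from compound 2 to compound 3 (beyond the scatter), though the rise may not clear the usual scatter. Compound 3 is estimated at 60%, within a range from 30% to 85%.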

Compound 3, a percentage reported as inhibition, at one concentration (the size of the read-out at that concentration, not a potency): > 80%
Compound 3 gave a limit, no number (the forecaster's own chance of this, stated with the estimate: 15%); middle value at least 20 percentage points from the limit.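

In this assay the change to 3-hydroxypropyl in place of cyclopentylcarbonyl on a nitrogen on an aromatic ring gives a number at least 33 percentage points higher from compound 2 to compound 3 (beyond the scatter) and so marks this nitrogen as a place where the choice of group matters. The earlier compounds shown here offered no pair differing in one place, so they could not show this. For compound 3 the reading of > 80% is a limit of the assay and not a number.

How large the rise truly is stays unread because the reading of compound 3 is such a limit: the limit of > 80% in this assay, at which 2 of the 3 values shown sit. The compounds shown also do not separate the loss of the ring and carbonyl from the gain of the hydrogen-bond donor, a question on which a cyclopentyl group without the carbonyl, or a propyl chain ending in an amine, would bear.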